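This account rests on a few compounds, and the source may have more. Where it says the series, first, only, none or still open, it means among the compounds named here.

Compound 1 `O=C(Nc1ccc(Oc2ccncc2-c2cccnc2)c(F)c1)c1nn(-c2cccc(F)c2)c(=O)c2ccccc12` and compound 2 `O=C(Nc1ccc(Oc2ccncc2-c2cccnc2)c(F)c1)c1nn(-c2ccccc2)c(=O)c2ccccc12` share one core, while compound 3 `Cn1cc(-c2ccccc2)cc(C(=O)Nc2ccc(Oc3ccncc3-c3cccnc3)c(F)c2)c1=O` and compound 4 `Cn1cc(-c2ccc(F)cc2)cc(C(=O)Nc2ccc(Oc3ccncc3-c3cccnc3)c(F)c2)c1=O` share another; the difference between the two cores is not broken down here. In a functional assay on MDA-MB-231 cells (Homo sapiens) for cytotoxicity, read by MTT assay, with a stated time of 72 h (on this read-out higher numbers stand for weaker inhibition and lower numbers for stronger inhibition), compound 1 gives 72 nM, compound 2 gives 8200 nM, and compound 3 gives 9500 nM. Within the first core, one change, (fluoro in place of hydrogen on an aromatic carbon), produced a 110-fold lower number from compound 2 to compound 1 (2.06 log units; beyond the scatter). Compound 4 carries the same kind of change, (fluoro in place of hydrogen on an aromatic carbon), but there the fluoro sits para to a large group rather than meta to it, and on a different core. Because the earlier change gave a 110-fold lower number from compound 2 to compound 1 (2.06 log units; beyond the scatter), a lower number is expected for compound 4 in this assay, though a smaller step of about a 6.3-fold lower number from compound 3 to compound 4 (0.80 log units; beyond the scatter) seems more likely given the altered place and core. The estimate for compound 4 is therefore 1500 nM, between 200 nM and 8000 nM.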

Compound 4, half-maximal inhibitory concentration: 11900 nM
For compound 4 the middle estimate is 7.9-fold (0.90 log units) below the measured one; measured number outside the range, above it.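

In this assay, fluoro in place of hydrogen gave a 1.3-fold higher number from compound 3 to compound 4 (0.10 log units; within the scatter), so on this core the change made no clear difference. The change did not carry over from one core to the other with the same effect: the same change on two cores in this assay, a 110-fold lower number (2.06 log units; beyond the scatter) from compound 2 to compound 1 and a 1.3-fold higher number (0.10 log units; within the scatter) from compound 3 to compound 4, 140-fold (2.15 log units) apart, beyond the scatter of two such steps. Among these compounds, what this does not show is whether the core or the place of the fluoro accounts for the gap, as the two pairs differ in both and each core offers only one pair.

Still open, from the compounds shown here alone, is what a fluoro would do at a different place on the phenyl of compound 3. Also open, going by these compounds, is whether a chloro or a methoxy group in place of the fluoro would follow the pattern of either core.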